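Adding a methoxy to a level series

The source may report more compounds than this note shows. Statements on the series, on what has been measured and on what is new or still open speak of the compounds shown alone.

compound 1 `COc1cccc(-c2nn(-c3ccccc3)cc2C(Nc2nc3ccccc3s2)c2c(O)ccc3ccccc23)c1` gives 24800 nM
compound 2 `COc1ccc(-c2nn(-c3ccccc3)cc2C(Nc2nc3ccccc3s2)c2c(O)ccc3ccccc23)cc1` gives 26200 nM
compound 3 `Oc1ccc2ccccc2c1C(Nc1nc2ccccc2s1)c1cn(-c2ccccc2)nc1-c1ccc(I)cc1` gives 23100 nM

In a functional assay on A549 cells (Homo sapiens) for antiproliferative activity, read by MTT assay, with a stated time of 48 h (a higher number here means a weaker inhibitor, a lower number a stronger inhibitor), the three compounds lie within the scatter of one another, so compound 1 (24800 nM) stands level with compound 2 and compound 3 and holds no distinct place among them.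

Compound 4 `COc1cccc(-c2nn(-c3ccccc3)cc2C(Nc2nc3ccc(OC)cc3s2)c2c(O)ccc3ccccc23)c1` differs from compound 1 at one site (methoxy in place of hydrogen on an aromatic carbon). There, methoxy takes the place of hydrogen on an aromatic carbon, which turns 1,3-benzothiazol-2-yl into 6-methoxy-1,3-benzothiazol-2-yl.

The measured steps bear on this only indirectly. All three (a 1.1-fold higher number from compound 1 to compound 2 (0.02 log units; within the scatter)), (a 1.1-fold lower number from compound 1 to compound 3 (0.03 log units; within the scatter)) and (a 1.1-fold lower number from compound 2 to compound 3 (0.05 log units; within the scatter)) alter the methoxyphenyl or iodophenyl group and leave the 1,3-benzothiazol-2-yl group untouched. Each stays within the scatter. The data therefore hold no direct measurement of a methoxy at the new site, only a series that has not moved so far.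

With nothing pointing either way, no change beyond the scatter is expected in this assay, and the range is kept wide for that reason. The expected step is small (a 1.1-fold lower number from compound 1 to compound 4 (0.03 log units; within the scatter)). For compound 4 the estimate is 23000 nM (expected range 10000 nM to 50000 nM).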

Compound 4, half-maximal inhibitory concentration: 88100 nM
Compound 4: the middle estimate sits 3.8-fold (0.58 log units) below what was measured; the measured number lies above the stated range.
By their numbers in this assay, from the lowest: compounds 3, 1 and 2 (each within the scatter of the next); then compound 4.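

In this assay, the 1,3-benzothiazol-2-yl group proves to be a place where the series does move: a 3.6-fold higher number from compound 1 to compound 4 (0.55 log units; beyond the scatter). The earlier steps shown here, which exchanged only the methoxyphenyl and iodophenyl groups, had all stayed within the scatter, so the flat picture they gave does not extend to this part of the molecule, where a methoxy on the aromatic carbon that is meta to a fused ring and para to a fused ring gives a weaker inhibitor than hydrogen does. Going by these compounds alone, nothing available explains this loss, and the single step, modest in size, gives no reason for it.

The compounds shown leave open whether the loss belongs to methoxy itself or would follow any group at this carbon, such as fluoro, methyl or an amine. They also leave open whether the same methoxy would cost as much on the 4-methoxyphenyl and 4-iodophenyl compounds, since the step is known only from the 3-methoxyphenyl compound.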